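Replacing an Amine Substituent with a Hydroxylated Amide

The source may hold more compounds than are shown below. What is called first, only, known or untested is meant among the compounds shown, and "the series" means these compounds.

Measured so far:
- Compound 1, `CNC[C@@H]1CCCc2cc(S(=O)(=O)c3cc[nH]c3)ccc21`: 0.159 nM
- Compound 2, `NC(=O)CNC[C@@H]1CCCc2cc(S(=O)(=O)c3cccc(F)c3)ccc21`: 0.1 nM

In an assay on isolated protein for displacement of a labelled ligand from 5-hydroxytryptamine receptor 6 (Homo sapiens) (on this read-out lower numbers stand for stronger inhibition and higher numbers for weaker inhibition), compound 2 gives 0.1 nM, the lowest number of the two, while compound 1 gives 0.159 nM; the two values lie within the usual scatter of each other, so neither stands apart. Compound 3, `CC(C)(O)C(=O)NC[C@@H]1CCCc2cc(S(=O)(=O)c3cccc(F)c3)ccc21`, has not been measured. It differs from compound 2 in one place: (1-hydroxy-1-methylethyl)carbonyl in place of carbamoylmethyl on an amine nitrogen. For the measured compounds named here, for compound 3 a step from compound 2 of a 3.0-fold higher number from compound 2 to compound 3 (0.48 log units; beyond the scatter) toward a higher number is expected, since no measured pair shows what this change does. The estimate for compound 3 is 0.3 nM, between 0.08 nM and 1.2 nM.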

Compound 3, inhibition constant: 2 nM
Beside the measured number, compound 3's estimate is 6.7-fold (0.82 log units) below it; the measured number lies above the stated range.
By their numbers in this assay, from the lowest: compounds 2 and 1 (each within the scatter of the next); then compound 3.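

In this assay putting (1-hydroxy-1-methylethyl)carbonyl in place of carbamoylmethyl on this amine nitrogen gives a 20-fold higher number from compound 2 to compound 3 (1.30 log units; beyond the scatter) and so shows that the group held here matters for this read-out. Compounds 1 and 2 could not show this, since they differ in more than one place. No measurement shown here accounts for the size of the step.

Still open, on these data alone, is whether the rise goes with the carbonyl on the nitrogen or with the hydroxy and methyl groups. An acetyl or a 2-hydroxyethyl group on the same nitrogen would separate the two.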